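Solubility notes on an aryloxy-quinoline series

This account rests on a few compounds, and the source may have more. Where it says the series, first, only, none or still open, it means among the compounds named here.

Measured compounds:
compound 1 `c1ccc(Oc2ccc3c(NCCCNCc4ccco4)ccnc3c2)cc1`: 14500 nM
compound 2 `Clc1ccc(Oc2ccc3c(NCCCNCc4ccco4)ccnc3c2)cc1`: 14500 nM
compound 3 `COc1ccc(F)cc1CNCCCNc1ccnc2cc(Oc3ccccc3)ccc12`: 14500 nM

The read-out throughout is a physicochemical assay for solubility, with a stated time of 18 h, at pH 7.4; a higher number here means a more soluble compound, a lower number a less soluble compound. In this assay compound 1 gives 14500 nM, compound 2 gives 14500 nM and compound 3 gives 14500 nM; the three values are level at the digits shown.

Two single changes connect them. From compound 1 to compound 2 the change is chloro in place of hydrogen on an aromatic carbon, and the step of no change at the digits printed from compound 1 to compound 2 (within the scatter). From compound 1 to compound 3 the change is 5-fluoro-2-methoxyphenyl in place of furan-2-yl on a saturated chain carbon bound to an amine nitrogen, with the step of no change at the digits printed from compound 1 to compound 3 (within the scatter). Compound 3 thus stands level with compound 1 and compound 2; no ordering among the three can be read from these numbers.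

Compound 4 `COc1ccc(F)cc1CNCCCNc1ccnc2cc(Oc3ccc(Cl)cc3)ccc12` is not yet measured. It differs from compound 3 by chloro in place of hydrogen on an aromatic carbon. Among the compounds with values here, this is the same change as the one from compound 1 to compound 2: the place lines agree word for word, a chloro in place of hydrogen on an aromatic carbon of a six-membered aromatic ring of carbon only, para to a large group. The two cores on which it is made differ by 5-fluoro-2-methoxyphenyl in place of furan-2-yl on a saturated chain carbon bound to an amine nitrogen, the only difference between them.

Within the data shown here, the expectation for compound 4 rests on the one earlier instance: because no change at the digits printed from compound 1 to compound 2 (within the scatter) was within scatter, and because no change at the digits printed from compound 1 to compound 3 (within the scatter) was also within scatter, the step from compound 3 to compound 4 is expected to be no change at the digits printed from compound 3 to compound 4 (within the scatter). The estimated solubility of compound 4 is 14500 nM, with an expected range from 7000 nM to 29000 nM.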

Compound 4, solubility: 14500 nM
Compound 4: the middle estimate sits on the measured number at the digits printed; measured number inside the range.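

In this assay chloro in place of hydrogen on an aromatic carbon, para to a large group, reads no change at the digits printed from compound 3 to compound 4 (within the scatter) on the core of compound 3, and the earlier reading on the core of compound 1 was no change at the digits printed from compound 1 to compound 2 (within the scatter), so the change gives no readable step on either core. The other new step, no change at the digits printed from compound 2 to compound 4 (within the scatter), agrees with the reading no change at the digits printed from compound 1 to compound 3 (within the scatter) and places 5-fluoro-2-methoxyphenyl and furan-2-yl level both with and without the chloro. This does not show that a size of effect carries from one core to another, since no step here has a size beyond the scatter, and two cores sharing one printed value are a narrow test of any such transfer; nothing shown bears on why all four values coincide.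

Still open, from the compounds shown here alone, is whether the chloro stays as silent on a core whose value sits away from the one shared by these four compounds. Also open, going by these compounds, is how the series reads with a carboxylic acid or an amine on the phenoxy ring in place of the chloro, or with a longer chain linking the two amine nitrogens.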